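This account rests on a few compounds, and the source may have more. Where it says the series, first, only, none or still open, it means among the compounds named here.

Measured so far:
compound 1, `O=C(Nc1cccc(-n2cc(-c3ccncc3)c(-c3ccc(Cl)c(O)c3)n2)c1)Nc1ccc(Cl)c(Cl)c1`: > 32500 nM
compound 2, `COc1cc(-c2nn(-c3cccc(NC(=O)c4ccc(Cl)c(C(F)(F)F)c4)c3)cc2-c2ccncc2)ccc1Cl`: > 32500 nM

All values here come from a functional assay on PC-3 cells (Homo sapiens) for inhibition, read by sulforhodamine B assay, with a stated time of 48 h; on this read-out higher numbers stand for lower toxicity in this test and lower numbers for higher toxicity in this test. For compound 1 the value > 32500 nM is a limit of the test and not a number. For compound 2 the value > 32500 nM is likewise a limit and not a number. Among the measured compounds shown here, compound 2 thus stands where every value so far stands, at the limit, as summed up in the limit of > 32500 nM in this assay, at which 2 of the 2 values shown sit. For the measured compounds named here, no compound has given a number in this assay, and no pair of measured compounds differs in a single place, so no measured step is available for comparison.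

Compound 3, `COc1cc(-c2nn(-c3cccc(NC(=O)c4cccc(C(F)(F)F)c4)c3)cc2-c2ccncc2)ccc1Cl`, has not been measured. It differs from compound 2 in one place: hydrogen in place of chloro on an aromatic carbon. With both measured compounds at the limit, no step beyond the scatter is expected; the estimated step is a step that the limit leaves unreadable from compound 2 to compound 3. For compound 3 the value expected in this assay is 40000 nM, within a range from 20000 nM to 100000 nM, and a report of only a limit is expected to be the most likely outcome.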

Compound 3, concentration lethal to 50% of the cells: > 50000 nM
Compound 3: no number, only a limit; the forecaster's own chance of this, stated with the estimate: 75%; at least 1.2-fold (0.09 log units) between middle value and limit.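

Compound 2 and compound 3 both give only a limit and not a number in this assay, and no step can be read for hydrogen in place of chloro on an aromatic carbon. The compounds shown leave open where any member of the series would give a number in this assay, and whether the chloro affects that number.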